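This account rests on a few compounds, and the source may have more. Where it says the series, first, only, none or still open, it means among the compounds named here.

Compound 1 `S=C(N/N=C/c1ccccc1Cl)Nc1nc2ccc(Cl)cc2s1`: 300 mg/kg
Compound 2 `Oc1ccc(/C=N/NC(=S)Nc2nc3ccc(Cl)cc3s2)cc1`: 100 mg/kg

Both compounds share one core and were tested in a functional assay on the whole organism with Mus musculus as the target, in the maximal electroshock model, with a stated time of 0.5 h; on this read-out higher numbers stand for an effect only at larger amounts of compound and lower numbers for an effect already at smaller amounts. For the measured compounds named here, compound 2 gives the lowest of the two numbers; its only neighbour, compound 1, sits a modest step away, as a 3.0-fold lower number from compound 1 to compound 2 (0.48 log units; beyond the scatter) shows. Compound 3 `S=C(N/N=C/c1ccc(Cl)cc1)Nc1nc2ccc(Cl)cc2s1` has not been measured yet. It differs from compound 2 by chloro in place of hydroxy on an aromatic carbon. Going by the values given here, no measured step swaps exactly these two groups at the same place. Among the compounds with values here, the one step at hand exchanges a chloro-bearing ring for a hydroxy-bearing ring and at the same time moves the group, so it speaks to the present change only in part, and it lowered the number by a 3.0-fold lower number from compound 1 to compound 2 (0.48 log units; beyond the scatter). Replacing the hydroxy with chloro may reverse part of that, so a rise of a 2.0-fold higher number from compound 2 to compound 3 (0.30 log units; within the scatter) is expected for compound 3. Compound 3 is therefore estimated at 200 mg/kg, within 100 mg/kg to 450 mg/kg.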

Compound 3, minimum effective dose in the Mus musculus assay: 300 mg/kg
Compound 3: the middle estimate sits 1.5-fold (0.18 log units) below what was measured; the measured number falls inside the stated range.
By their numbers in the Mus musculus assay, from the lowest: compound 2; then compounds 1 and 3 (each within the scatter of the next).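

In the Mus musculus assay, 2-chlorophenyl to 4-chlorophenyl gives no change at the digits printed from compound 1 to compound 3 (within the scatter), while chloro in place of hydroxy at the same place gives a 3.0-fold higher number from compound 2 to compound 3 (0.48 log units; beyond the scatter), so the earlier step, which mixed two changes, can now be pulled apart: among these three compounds, the hydroxy goes with the lower number, and the place of the chloro does not shift it. In a physicochemical assay for lipophilicity, in phosphate buffer, measured as octanol-water partition (on this read-out higher numbers stand for higher lipophilicity and lower numbers for lower lipophilicity), compound 2 gives 4.78 and compound 3 gives 5.52. The swap that raises the dose needed therefore also raises lipophilicity, which may contribute to the loss, though a single pair cannot establish this: the measured partition coefficient of compound 2, 4.78, and of compound 3, 5.52, a number 0.74 log units higher (beyond the scatter)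

Going by these compounds, whether the lower number follows the hydroxy itself or simply the lower lipophilicity stays open. A methoxy or an amine at this place would help separate the two.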